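A few compounds are considered here, and "the series" means these few. Any claim that something is new, unique, unknown or untested is made for them only; others in the source may bear on it.

Compound 1 `Cc1cc(C(=O)O)ccc1CN1CCC[C@H](O[C@H](CF)c2cc(Cl)cc(Cl)c2)[C@@H]1c1ccccc1` sets the starting point: in an assay on isolated protein for activation of cGMP-dependent protein kinase 1 (Homo sapiens), read by ADP-Glo, with stated times of 30 min and 2 h, in the presence of a further agent that is not named here (a lower number here means that less compound is needed, a higher number that more compound is needed for the effect), compound 1 gives 9100 nM, the highest of the three numbers in hand. Compound 2 `O=C(O)c1ccc(CN2CCC[C@H](O[C@H](CO)c3cc(Cl)cc(Cl)c3)[C@@H]2c2ccccc2)c([N+](=O)[O-])c1` gives 520 nM, and compound 3 `Cc1cc(C(=O)O)ccc1CN1CCC[C@H](O[C@H](CS(C)(=O)=O)c2cc(Cl)cc(Cl)c2)[C@@H]1c1ccccc1` gives 330 nM.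

Compound 4 `Cc1cc(C(=O)O)ccc1CN1CCC[C@H](O[C@H](CO)c2cccc(Cl)c2)[C@@H]1c1ccccc1` differs from compound 1 by a group of 10 heavy atoms (8 carbon, 1 oxygen, 1 chlorine; one six-membered aromatic ring of carbon only) in place of a group of 11 heavy atoms (8 carbon, 1 fluorine, 2 chlorine; one six-membered aromatic ring of carbon only), on an oxygen on a saturated carbon: the 1-(3-chlorophenyl)-2-hydroxyethyl group replaces a group that carried a fluorine and two chlorines, on the oxygen on a saturated carbon whose other neighbour is a saturated ring carbon.

Among the compounds with values here, one measured step bears on this. Exchanging the fluoro for a methylsulfonyl on the saturated chain carbon gave a 28-fold lower number from compound 1 to compound 3 (1.44 log units; beyond the scatter). Compound 2, which carries a hydroxyl on that same chain carbon together with a nitro group, shows a far lower number than compound 1, though its two changes cannot be separated. Compound 4 also loses one chlorine, for which no comparison exists.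

The hydroxyl is therefore expected to bring a marked improvement, tempered by the missing chlorine, so the step from compound 1 to compound 4 is estimated at a 6.1-fold lower number from compound 1 to compound 4 (0.78 log units; beyond the scatter). Compound 4 is expected to give about 1500 nM, between 400 nM and 6000 nM.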

Compound 4, half-maximal effective concentration: 1300 nM
For compound 4 the middle estimate is 1.2-fold (0.06 log units) above the measured one; measured number inside the range.
By their numbers in this assay, from the lowest: compounds 3 and 2 (each within the scatter of the next); then compound 4; then compound 1.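

On an oxygen on a saturated carbon, the 1-(3-chlorophenyl)-2-hydroxyethyl group gives a 7.0-fold lower number from compound 1 to compound 4 (0.85 log units; beyond the scatter) in this assay, so the number falls even though the entering group carries one chlorine fewer than the group it replaces. Within the data shown here, until now, the only single-place step at this group was the methylsulfonyl exchange; this step shows that a change that also removes a chlorine can still lower the number beyond the scatter. None of the data shown explains this step.

Compound 4 changes the chain substituent and the chlorines together, so the compounds shown cannot apportion the step between the hydroxyl and the lost chlorine. They also leave open how an amine on that chain carbon, or a methoxy group in place of the hydroxyl, would compare.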